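Trading a Chain Carbon for Oxygen at the Aryl Ether

The source may report more compounds than this note shows. Statements on the series, on what has been measured and on what is new or still open speak of the compounds shown alone.

Compound 1 `COc1cc(C(C)(C)C)ccc1C/N=C(\S)NCc1ccc(NS(C)(=O)=O)cc1`: 2400 nM
Compound 2 `CCOc1cc(C(C)(C)C)ccc1C/N=C(\S)NCc1ccc(NS(C)(=O)=O)cc1`: 1100 nM
Compound 3 `CCCOc1cc(C(C)(C)C)ccc1C/N=C(\S)NCc1ccc(NS(C)(=O)=O)cc1`: 250 nM

These three compounds share one core and differ only in the chain attached to an oxygen on the aromatic ring. In a functional assay for inhibition of Vanilloid receptor (Rattus norvegicus) (on this read-out lower numbers stand for stronger inhibition and higher numbers for weaker inhibition), compound 3 gives 250 nM, the lowest number of the three; each step toward it lies beyond the scatter, so within this set it is the strongest inhibitor. The numbers fall as the chain grows: a 2.2-fold lower number from compound 1 to compound 2 (0.34 log units; beyond the scatter), then a 4.4-fold lower number from compound 2 to compound 3 (0.64 log units; beyond the scatter), and over the whole span a 9.6-fold lower number from compound 1 to compound 3 (0.98 log units; beyond the scatter).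

Compound 4 `COCOc1cc(C(C)(C)C)ccc1C/N=C(\S)NCc1ccc(NS(C)(=O)=O)cc1` carries the change (methoxy in place of ethyl on a saturated chain carbon bound to an oxygen on an aromatic ring); cut one bond further out, the same difference reads propoxy to methoxymethoxy. The chain keeps its count of heavy atoms, but one carbon becomes an oxygen. Every measured step concerns adding carbons to this chain; none tests an oxygen inside it, so those steps bear only loosely on the new change and the expectation is uncertain. Compound 4 is expected to give about 600 nM, within a range from 200 nM to 2000 nM. This estimate amounts to a 2.4-fold higher number from compound 3 to compound 4 (0.38 log units; beyond the scatter), a modest loss relative to compound 3, reflecting that an equally long chain without the measured pattern of added carbons may not retain the full gain.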

Compound 4, half-maximal inhibitory concentration: 500 nM
Estimate against measurement, compound 4: 1.2-fold (0.08 log units) above, within the range that was stated.
By their numbers in this assay, from the lowest: compounds 3 and 4 (each within the scatter of the next); then compound 2; then compound 1.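

Replacing a carbon in the chain with an oxygen does not separate the two compounds in this assay: a 2.0-fold higher number from compound 3 to compound 4 (0.30 log units; within the scatter), so the propoxy and methoxymethoxy chains cannot be ranked against each other here. The earlier compounds shown here varied only the number of carbons in the chain, whereas compound 4 shows that this position can also hold a chain with an oxygen inside it and still give a lower number than either shorter chain, with a 2.2-fold lower number from compound 2 to compound 4 (0.34 log units; beyond the scatter) and a 4.8-fold lower number from compound 1 to compound 4 (0.68 log units; beyond the scatter), both beyond the scatter. No measurement offered here explains why the oxygen is accommodated in this way.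

The compounds shown leave open whether the fall in the numbers continues with a longer chain, such as butoxy, or whether it stops at the length of the propoxy chain. They also leave open how much the exact place of the oxygen matters, a question that 2-methoxyethoxy could address, and whether an amine within the chain would give a similar number to the oxygen of compound 4.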